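Swapping the chlorophenyl arm for a fluoropyridine

The source may report more compounds than this note shows. Statements on the series, on what has been measured and on what is new or still open speak of the compounds shown alone.

This small set concerns compounds built on one shared core, tested in an in vitro assay on HEK385-7 cells for displacement of a labelled ligand from prostaglandin D2 receptor 2 (Homo sapiens); a lower number here means a stronger inhibitor, a higher number a weaker inhibitor. Compound 1, `Nc1nc(-c2ccc(Cl)cc2)c(CC(=O)O)s1`, carries only a small amino group on the core and gives > 100000 nM, a limit of the measurement rather than a number (the limit of > 100000 nM in this assay, at which 1 of the 3 values shown sits). Compound 2, `O=C(O)Cc1sc(C(c2ccc(F)cc2)c2ccc(F)cc2)nc1-c1ccc(Cl)cc1`, carries a large bis(fluorophenyl)methyl group instead and gives 9.7 nM. Compound 3, `O=C(O)Cc1sc(C(c2ccccc2)c2ccc(F)c(F)c2)nc1-c1ccc(F)cc1`, a close relative with a different pair of aryl rings, gives 10 nM, which sits within the usual scatter of the value for compound 2.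

Compound 4, `O=C(O)Cc1sc(C(c2ccc(F)cc2)c2ccc(F)cc2)nc1-c1ccnc(F)c1`, has not yet been measured. It differs from compound 2 in one place: 2-fluoropyridin-4-yl in place of 4-chlorophenyl on an aromatic carbon. For the measured compounds named here, since no measured pair in this set shows the effect of such a swap, the expectation here rests only on the two strong values of compound 2 and compound 3. Compound 4 is expected to give about 25 nM, within a range from 8 nM to 80 nM. That amounts to an expected 2.6-fold higher number from compound 2 to compound 4 (0.41 log units; beyond the scatter) toward a slightly weaker inhibitor, close to the edge of the scatter.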

Compound 4, half-maximal inhibitory concentration: 0.48 nM
Compound 4: middle estimate off by 52-fold (1.72 log units), on the high side, and the stated range ends above it.
By their numbers in this assay, from the lowest: compound 4; then compounds 2 and 3 (each within the scatter of the next). At a limit, above all of these: compound 1.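

On the aromatic carbon next to the ring nitrogen, putting 2-fluoropyridin-4-yl in place of 4-chlorophenyl gives a 20-fold lower number from compound 2 to compound 4 (1.31 log units; beyond the scatter) in this assay, a large step. For the compounds shown here, compounds 1, 2 and 3 all carry a six-membered aromatic ring of carbon only at this position, so they could not show that a ring with a hetero atom is accepted here, or that this single change can move the number so far. No measured property in the data accounts for this gain.

From the compounds shown here alone, the ring nitrogen and the fluorine enter together, so it remains open which of them carries the step. A plain pyridin-4-yl group, without the fluorine, or a 2-aminopyridin-4-yl group, with an amine in its place, would be needed to separate the two.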